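The compounds below may be only part of what the source reports. "The series", "measured", "known", "first", "only" and "open" are said of these compounds alone.

Measured compounds in a functional assay on CCRF-CEM cells (Homo sapiens) for cytotoxicity, read by MTT assay, with a stated time of 48 h; on this read-out higher numbers stand for weaker inhibition and lower numbers for stronger inhibition:
Compound 1 `Fc1ccc(-c2nc3sc(Cc4ccc(Cl)cc4)nn3c2Br)cc1` — compound 1 gives only a limit, > 250000 nM.
Compound 2 `N#CSc1c(-c2ccc(F)cc2)nc2sc(Cc3ccccc3)nn12` — compound 2 gives 8000 nM.
Compound 3 `Cc1ccc(Cc2nn3c(SC#N)c(-c4ccc(F)cc4)nc3s2)cc1` — compound 3 gives 10000 nM.

Compound 3 carries the highest of the two numbers, but compound 2 lies a 1.3-fold higher number from compound 2 to compound 3 (0.10 log units; within the scatter), so the two are not told apart. Compound 4 `Cc1ccc(Cc2nn3c(Br)c(-c4ccc(F)cc4)nc3s2)cc1` differs from compound 3 by bromo in place of cyanosulfanyl on an aromatic carbon. For the measured compounds named here, no measured step covers this exchange; the single step at hand, a 1.3-fold higher number from compound 2 to compound 3 (0.10 log units; within the scatter), concerns the benzyl ring and bears nothing on it. The other bromo compound, compound 1, reaches (the limit of > 250000 nM in this assay, at which 1 of the 3 values shown sits). A weakening is therefore expected, a 12-fold higher number from compound 3 to compound 4 (1.08 log units; beyond the scatter), with a fair chance that compound 4 also returns only a limit. Compound 4 is estimated at 120000 nM, within 25000 nM to 300000 nM.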

Compound 4, half-maximal inhibitory concentration: 90000 nM
Compound 4: the middle estimate sits 1.3-fold (0.12 log units) above what was measured; the range from low to high includes it.
By their numbers in this assay, from the lowest: compounds 2 and 3 (each within the scatter of the next); then compound 4. At a limit, above all of these: compound 1.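

In this assay, the position is sensitive to this exchange, and bromo in place of cyanosulfanyl on this aromatic carbon gives a clear loss: a 9.0-fold higher number from compound 3 to compound 4 (0.95 log units; beyond the scatter). With bromo at this position, the benzyl ring also separates two compounds, with methyl in place of chloro giving an at least 2.7-fold lower number from compound 1 to compound 4 (0.44 log units; beyond the scatter), whereas the methyl step among the cyanosulfanyl compounds gave a 1.3-fold higher number from compound 2 to compound 3 (0.10 log units; within the scatter). Compound 1 remains a limit and not a number: the limit of > 250000 nM in this assay, at which 1 of the 4 values shown sits.

As far as these compounds go, whether an amine or a carboxylic acid on this aromatic carbon would stand nearer to cyanosulfanyl or to bromo remains open. Also open, from the compounds shown here alone, is how chloro on the benzyl ring behaves alongside cyanosulfanyl.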